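Hexanoyl Extension of an Acetyl Oxazolopyridine Ketone

The compounds below may be only part of what the source reports. "The series", "measured", "known", "first", "only" and "open" are said of these compounds alone.

Measured compounds:
compound 1 `O=C(CCCc1ccccc1)c1nc2ncccc2o1` with 2240 nM
compound 2 `O=C(CCCCc1ccccc1)c1nc2ncccc2o1` with 204 nM
compound 3 `CC(=O)c1nc2ncccc2o1` with > 10000 nM

Three ketones sharing one core have been examined in an assay on HEK-293T cells for inhibition of diacylglycerol lipase-alpha (Homo sapiens), read by colorimetric assay; a higher number here means a weaker inhibitor, a lower number a stronger inhibitor. Compound 1 gives 2240 nM in this assay, and compound 2 gives 204 nM there; the change between them is an 11-fold lower number from compound 1 to compound 2 (1.04 log units; beyond the scatter). For compound 3 only a limit is known, (the limit of > 10000 nM in this assay, at which 1 of the 3 values shown sits), so its standing on the numbers is at the weak end with no number attached.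

Compound 4 `CCCCCC(=O)c1nc2ncccc2o1` arises from compound 3 by the change (butyl in place of hydrogen on a saturated chain carbon bound to a carbonyl carbon), that is, a butyl group replaces a hydrogen on the chain carbon that carries the carbonyl. Going by the values given here, the single measured step that bears on it is the chain-lengthening step from compound 1 to compound 2, which was large and moved this assay to a lower number. Compound 4 carries no phenyl, so the expected step is smaller and uncertain; it is estimated as an at least 3.3-fold lower number from compound 3 to compound 4 (0.52 log units; beyond the scatter). Compound 4 is therefore expected to give 3000 nM, with a range from 700 nM to 12000 nM.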

Compound 4, half-maximal inhibitory concentration: > 10000 nM
Compound 4: a limit, no number; the forecaster's own chance of this, stated with the estimate: 30%; at least 3.3-fold (0.52 log units) between middle value and limit.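

Lengthening the methyl of compound 3 to the pentyl of compound 4 brings no readable change in this assay; each compound stands at a limit of the assay, so the step between them cannot be read: the limit of > 10000 nM in this assay, at which 2 of the 4 values shown sit.

Replacing the phenyl at the chain end of compound 2 with methyl gives an at least 49-fold higher number from compound 2 to compound 4 (1.69 log units; beyond the scatter). Replacing the phenyl of compound 1 with ethyl gives an at least 4.4-fold higher number from compound 1 to compound 4 (0.64 log units; beyond the scatter), so among the compounds shown, only the two chains ending in phenyl give a number rather than a limit.

Going by these compounds, it remains open whether a longer chain without phenyl, such as octyl, would give a number in this assay. On these data alone, it is equally open how a carboxylic acid or an amine at the chain end would compare with the phenyl of compound 2.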